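This account rests on a few compounds, and the source may have more. Where it says the series, first, only, none or still open, it means among the compounds named here.

Compound 3 `CC(=O)c1ccc(-c2cn3ccnc3c(-c3ccc4ncn(C5CCCCC5)c4c3)n2)cc1` carries a 4-acetylphenyl on the shared core and in a functional assay on K562 cells (Homo sapiens) for inhibition, read by sulforhodamine B assay, with a stated time of 48 h, tested at 10 uM (a lower number here means less inhibition, a higher number more inhibition at the concentration tested (going by the name of the read-out)), compound 3 gives 9.6%. Among the measured compounds shown here, compound 3 stands lowest of the three numbers measured so far. Nearest is compound 1 `Brc1cn2ccnc2c(-c2ccc3ncn(C4CCCCC4)c3c2)n1`, with bromo in that place; in this assay compound 1 gives 18%, and the step was a number 8.4 percentage points lower from compound 1 to compound 3 (within the scatter). Furthest is compound 2 `COc1ccc(-c2cn3ccnc3c(-c3ccc4ncn(C5CCCCC5)c4c3)n2)cc1`, with 4-methoxyphenyl; in this assay compound 2 gives 92%, and the step was a number 82.4 percentage points lower from compound 2 to compound 3 (beyond the scatter).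

Compound 4 `FC(F)(F)c1cccc(-c2cn3ccnc3c(-c3ccc4ncn(C5CCCCC5)c4c3)n2)c1` differs from compound 3 in one place: 3-(trifluoromethyl)phenyl in place of 4-acetylphenyl on an aromatic carbon. For the measured compounds named here, the steps that bear on this are the substituent swaps on the same aromatic carbon: a number 74 percentage points higher from compound 1 to compound 2 (beyond the scatter) and a number 82.4 percentage points lower from compound 2 to compound 3 (beyond the scatter) were both large, while a number 8.4 percentage points lower from compound 1 to compound 3 (within the scatter) stayed within the scatter. Going by the values given here, the group on the phenyl thus spans the whole range seen, yet a trifluoromethyl there has no measured counterpart, and the acetyl and methoxy results point in opposite directions. Compound 4 is therefore expected to give a number in this assay near 35%, with a wide range from 5% to 80%. The expected step from compound 3 is a number 25.4 percentage points higher from compound 3 to compound 4 (beyond the scatter), an upward move of uncertain size rather than a confident prediction.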

Compound 4, a percentage reported as inhibition, at one concentration (the size of the read-out at that concentration, not a potency): 21.5%
For compound 4 the middle estimate is 13.5 percentage points above the measured one; measured number inside the range.
By their numbers in this assay, from the lowest: compounds 3, 1 and 4 (each within the scatter of the next, the first and the last beyond it); then compound 2.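

In this assay, a second phenyl group carrying something other than methoxy also falls far short of the methoxy compound, with a number 70.5 percentage points lower from compound 2 to compound 4 (beyond the scatter), so among the three phenyl-bearing compounds shown, only compound 2 stands high and compounds 3 and 4 do not. Swapping the bromo for 3-(trifluoromethyl)phenyl gives a number 3.5 percentage points higher from compound 1 to compound 4 (within the scatter), and the change between the two non-methoxy phenyl groups gives a number 11.9 percentage points higher from compound 3 to compound 4 (beyond the scatter), a step small beside the drop from compound 2 and one that alters both the substituent and its place on the phenyl at once. No measurement on hand offers an explanation for why the 4-methoxyphenyl group stands apart from the other groups at this aromatic carbon.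

The compounds shown leave open whether the high read-out of compound 2 depends on the methoxy itself or on where it sits on the phenyl, since the series holds no pair that changes only one of these. They also leave open whether other groups on the phenyl, such as a hydroxyl, an amine or a longer ether chain like ethoxy, would come near compound 2 or stay with compounds 3 and 4.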